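This account rests on a few compounds, and the source may have more. Where it says the series, first, only, none or still open, it means among the compounds named here.

Compound 1 `COc1ccc(C(=O)N2CCC(=CC(=O)N[C@@H]3CCN(Cc4ccc5cc(F)ccc5c4)C3)CC2)cc1OC`, compound 2 `COc1cccc(C(=O)N2CCC(=CC(=O)N[C@@H]3CCN(Cc4ccc5cc(F)ccc5c4)C3)CC2)c1O` and compound 3 `O=C(C=C1CCN(C(=O)c2cccc(F)c2)CC1)N[C@@H]1CCN(Cc2ccc3cc(F)ccc3c2)C1` share one core and differ only in the aryl group on the carbonyl carbon. In an in vitro ADME assay on microsomes from liver (Homo sapiens) for metabolic stability (on this read-out lower numbers stand for slow clearance and higher numbers for fast clearance), compound 1 gives 246 mL/min/kg, compound 2 gives 162 mL/min/kg and compound 3 gives 459 mL/min/kg. Compound 3 therefore holds the highest of the three numbers: the step of a 1.9-fold higher number from compound 1 to compound 3 (0.27 log units; within the scatter) stays within the scatter, whereas the step of a 2.8-fold higher number from compound 2 to compound 3 (0.45 log units; beyond the scatter) goes beyond it.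

Compound 4 `Cc1ccc(C(=O)N2CCC(=CC(=O)N[C@@H]3CCN(Cc4ccc5cc(F)ccc5c4)C3)CC2)c(O)c1` arises from compound 3 by the change (2-hydroxy-4-methylphenyl in place of 3-fluorophenyl on a carbonyl carbon). Within the data shown here, the step that bears most directly on it is the one between compound 2 and compound 3, since it too replaces a hydroxy-bearing aryl group by 3-fluorophenyl; read in the opposite direction, a 2.8-fold higher number from compound 2 to compound 3 (0.45 log units; beyond the scatter) suggests that bringing a hydroxyl back onto the ring goes with a lower number. The step of a 1.9-fold higher number from compound 1 to compound 3 (0.27 log units; within the scatter) points the same way but stays within the scatter. Compound 4 is thus expected to show a modest fall, a 2.1-fold lower number from compound 3 to compound 4 (0.32 log units; beyond the scatter), and its clearance in this assay is estimated at 220 mL/min/kg, within a range from 110 mL/min/kg to 440 mL/min/kg.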

Compound 4, clearance: 156 mL/min/kg
For compound 4 the middle estimate is 1.4-fold (0.15 log units) above the measured one, and the stated range covers the measured number.
By their numbers in this assay, from the lowest: compounds 4, 2, 1 and 3 (each within the scatter of the next, the first and the last beyond it).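

In this assay, the step to the 2-hydroxy-4-methylphenyl group, a 2.9-fold lower number from compound 3 to compound 4 (0.47 log units; beyond the scatter), gives a second hydroxy-bearing aryl group that lies beyond the scatter from 3-fluorophenyl on this carbonyl carbon, where compound 2 had been the only such case. The two hydroxy-bearing groups cannot be told apart, since a 1.0-fold lower number from compound 2 to compound 4 (0.02 log units; within the scatter) lies within the scatter, so the methyl and methoxy groups they carry leave no readable difference here. Compound 1 goes against a clean split by hydroxyl, as it has none and yet a 1.6-fold lower number from compound 1 to compound 4 (0.20 log units; within the scatter) also stays within the scatter.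

From the compounds shown here alone, whether the hydroxyl alone goes with the lower number stays open, as does where a plain 2-hydroxyphenyl, an aminophenyl or a carboxylic acid at this place would fall. Nothing available explains why compound 3 stands apart from compound 2 and compound 4.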